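The source may hold more compounds than are shown below. What is called first, only, known or untested is meant among the compounds shown, and "the series" means these compounds.

Measured in an ADME assay on KB cells (Homo sapiens) for cytotoxicity; a higher number here means that more compound is needed for the effect, a lower number that less compound is needed:
- compound 1 `COc1cc2c(c(OC)c1OC)C(=O)[C@]1(OC)C=C[C@H]2N(C(=O)OCC(C)C)N1C(=O)OCC(C)C` | > 300 ug/mL | a limit, not a number
- compound 2 `COC(=O)N1[C@@H]2C=C[C@@](OC)(C(=O)c3c2cc(OC)c(OC)c3OCc2ccc(Cl)cc2)N1C(=O)OC` | 55.9 ug/mL

Compound 1 stands at the limit of > 300 ug/mL in this assay, at which 1 of the 2 values shown sits, and so has no exact number. In this assay compound 2 gives a true number, 55.9 ug/mL, rather than a limit.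

Compound 3 `COc1cc2c(c(OCc3ccccc3F)c1OC)C(=O)[C@]1(OC)C=C[C@H]2N(C(=O)OCC(C)C)N1C(=O)OCC(C)C` keeps the core of compound 1 and changes it in one place: 2-fluorophenyl in place of hydrogen on a saturated chain carbon bound to an oxygen on an aromatic ring. This puts 2-fluorophenyl in place of hydrogen on a saturated chain carbon bound to an oxygen on an aromatic ring, turning methoxy into (2-fluorobenzyl)oxy.

Within the data shown here, no measured pair isolates this change, so the expectation is loose. Among the measured compounds shown here, the only numerical guide is compound 2 at 55.9 ug/mL, which suggests a move towards less compound being needed. The estimated step of an at least 3.7-fold lower number from compound 1 to compound 3 (0.57 log units; beyond the scatter) is therefore expected to be clear but uncertain in size. For compound 3 the estimate is 80 ug/mL, with an expected range from 20 ug/mL to 300 ug/mL in this measurement.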

Compound 3, concentration for half-maximal effect: 109 ug/mL
The estimate for compound 3 lay 1.4-fold (0.13 log units) below the measured number; the range from low to high includes it.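

In this assay, replacing methoxy with (2-fluorobenzyl)oxy on the core of compound 1 gives a true number: compound 3 gives 109 ug/mL. Among these compounds, this is the first one-place comparison at this position, and the change alone produces an at least 2.7-fold lower number from compound 1 to compound 3 (0.43 log units; beyond the scatter), so a much larger group on this oxygen is compatible with a stronger cytotoxic effect in these cells. The size of that step is only a lower bound, because compound 1 has a limit rather than a number: the limit of > 300 ug/mL in this assay, at which 1 of the 3 values shown sits.

The compounds shown leave open whether the fluorine contributes to the effect or whether the benzyl group alone would give the same result, which a plain benzyloxy group would test. They also do not show how a simple ethoxy chain or a benzyl group bearing an amine would behave at this position.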